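This account rests on a few compounds, and the source may have more. Where it says the series, first, only, none or still open, it means among the compounds named here.

Compound 2, drawn as `CCn1c(C(=O)N[C@@H](CO)CCCO)ccc1C(CC)(CC)c1ccc(OCS(=O)(=O)c2ccccc2)c(C)c1`, is tested in a functional assay on MCF7 cells (Homo sapiens) for antiproliferative activity, read by MTT assay, with a stated time of 24 h (on this read-out lower numbers stand for stronger inhibition and higher numbers for weaker inhibition), where it gives 29600 nM. Among the compounds with values here, of the two compounds measured so far it holds the higher number, but its neighbour compound 1, drawn as `CCn1c(C(=O)NC(C)(C)CO)ccc1C(CC)(CC)c1ccc(OCS(=O)(=O)c2ccccc2)c(C)c1`, gives 20700 nM, and the two values sit within the scatter of each other, so no order between them can be claimed. Within the data shown here, the only measured step, a 1.4-fold higher number from compound 1 to compound 2 (0.16 log units; within the scatter), swaps one side chain on the amide-type nitrogen for another without moving the number beyond the scatter.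

Compound 3, drawn as `CCn1c(C(=O)N[C@H](CC(=O)O)C(=O)O)ccc1C(CC)(CC)c1ccc(OCS(=O)(=O)c2ccccc2)c(C)c1`, has not yet been measured. It differs from compound 2 by a group of 8 heavy atoms (4 carbon, 4 oxygen; no ring) in place of a group of 7 heavy atoms (5 carbon, 2 oxygen; no ring), on an amide-type nitrogen, again on the amide-type nitrogen. Among the measured compounds shown here, the one step available bears directly on this place and was small, so the expected step in this assay is also small, and no direction beyond the scatter can be read from it. Compound 3 is therefore expected to give about 35000 nM, with a range from 12000 nM to 100000 nM; the estimated step of a 1.2-fold higher number from compound 2 to compound 3 (0.07 log units; within the scatter) is meant to lie within the usual scatter.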

Compound 3, half-maximal inhibitory concentration: > 50000 nM
Compound 3 gave a limit, no number; the forecaster's own chance of this, stated with the estimate: 20%; middle value at least 1.4-fold (0.15 log units) from the limit.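

The reading for compound 3 in this assay is a limit and not a number: the limit of > 50000 nM in this assay, at which 1 of the 3 values shown sits.

With 1,2-dicarboxyethyl in place of 1-(hydroxymethyl)-1-methylethyl on the amide-type nitrogen, the comparison gives an at least 2.4-fold higher number from compound 1 to compound 3 (0.38 log units; beyond the scatter). Within the data shown here, this is the first step at this place to pass the scatter, so the side chain here can move the number, which the earlier pair of compounds did not show. Among these compounds, the other comparison gives an at least 1.6-fold higher number from compound 2 to compound 3 (0.22 log units; that floor lies within the scatter), and that floor alone sets no order between those two compounds, so the clear separation so far holds for only one of the two neighbours.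

On these data alone, how far the true value of compound 3 lies past the limit stays unknown, so the full size of both steps remains open. The compounds shown also leave open what a side chain with a single carboxylic acid, an amine or a longer plain carbon chain on the same nitrogen would give, and whether any group at this place can bring the number clearly lower than in compound 1.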